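Moving the hydroxy group: from compound 2 to compound 3

The compounds below may be only part of what the source reports. "The series", "measured", "known", "first", "only" and "open" are said of these compounds alone.

Compound 2, with the structure `O=C(N/N=C/c1cccc(O)c1)c1cccnc1Nc1cccc(C(F)(F)F)c1`, gives 49% in a functional assay on the whole organism (strain Wistar) for inhibition, with Rattus norvegicus as the target, read by paw edema, with a stated time of 3 h, at a dose of 10 mg/kg by the intraperitoneal route; a lower number here means less inhibition, a higher number more inhibition at the dose given (going by the name of the read-out). For the measured compounds named here, that is the highest of the two numbers measured so far; the nearest is compound 1, `O=C(N/N=C/c1cccc(F)c1)c1cccnc1Nc1cccc(C(F)(F)F)c1`, which in this assay gives 37%. Going by the values given here, the one measured step, a number 12 percentage points higher from compound 1 to compound 2 (beyond the scatter), came from putting hydroxy in place of fluoro on an aromatic carbon.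

Compound 3, `O=C(N/N=C/c1ccc(O)cc1)c1cccnc1Nc1cccc(C(F)(F)F)c1`, is the next compound to be measured. It has the same atoms as compound 2, joined differently: 4-hydroxyphenyl in place of 3-hydroxyphenyl on a carbon with a double bond to nitrogen. Among the compounds with values here, no measured step shows what the change from 3-hydroxyphenyl to 4-hydroxyphenyl does; the only step available swapped one group for another in the same part of the molecule, so it bears on compound 3 only loosely, showing that a hydroxy on this ring is compatible with inhibition. With nothing to point in either direction, the expected step of a number 2 percentage points lower from compound 2 to compound 3 (within the scatter) is none beyond the scatter. Compound 3 is therefore estimated to give 47% in this assay, with a range of 30% to 64%.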

Compound 3, a percentage reported as inhibition, in the whole organism at one dose (the size of the read-out at that dose, not a potency): 59.5%
The estimate for compound 3 lay 12.5 percentage points below the measured number; measured number inside the range.
By their numbers in this assay, from the lowest: compound 1; then compound 2; then compound 3.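

Moving the hydroxy group and changing nothing else gives a number 10.5 percentage points higher from compound 2 to compound 3 (beyond the scatter) in this assay and so shows that, on this ring, it matters where the hydroxy sits and not only that it is present. The 4-hydroxyphenyl and 3-hydroxyphenyl groups have the same atoms and the same computed counts, yet they are not interchangeable on the carbon with a double bond to nitrogen. The wider swap of 4-hydroxyphenyl in place of 3-fluorophenyl gives a number 22.5 percentage points higher from compound 1 to compound 3 (beyond the scatter) and leaves compound 3 the highest of the three, though nothing measured here explains this result.

The compounds shown leave open whether the gain belongs to the hydroxy group itself, since a 4-fluorophenyl group would separate the effect of the swapped group from that of its new place on the ring. They also leave open whether a 4-methoxyphenyl or 4-aminophenyl group would hold, raise or lower the inhibition of paw edema, and so whether the hydrogen on the hydroxy oxygen is needed at all.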